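Hydroxy to Methoxy on a Shared Core: What to Expect

A few compounds are considered here, and "the series" means these few. Any claim that something is new, unique, unknown or untested is made for them only; others in the source may bear on it.

Compound 1 `O=C1OC[C@H](Cc2ccccc2)[C@H]1Cc1ccccc1O` carries a hydroxy group on one of its two aromatic rings. In a functional assay on HL-60 cells (Homo sapiens) for cytotoxicity, read by WST assay, with a stated time of 48 h (on this read-out higher numbers stand for an effect only at larger amounts of compound and lower numbers for an effect already at smaller amounts), compound 1 gives 83000 nM. Compound 2 `COc1ccccc1C[C@H]1C(=O)OC[C@@H]1Cc1ccccc1` differs from it by methyl in place of hydrogen on an oxygen on an aromatic ring; in this assay compound 2 gives 79000 nM, so the change made a 1.1-fold lower number from compound 1 to compound 2 (0.02 log units; within the scatter). Compound 3 `O=C1OC[C@H](Cc2ccccc2)[C@H]1Cc1ccc(O)cc1` keeps the hydroxy group but on a different position of the ring; in this assay compound 3 gives 88000 nM, and the move made a 1.1-fold higher number from compound 1 to compound 3 (0.03 log units; within the scatter). All three numbers therefore sit close together.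

Compound 4 `COc1ccc(C[C@H]2C(=O)OC[C@@H]2Cc2ccccc2)cc1` is not yet measured. It differs from compound 3 by methyl in place of hydrogen on an oxygen on an aromatic ring, the same change that turned compound 1 into compound 2. The core of compound 3 differs from that of compound 1 by 4-hydroxyphenyl in place of 2-hydroxyphenyl on a saturated chain carbon bound to a saturated ring carbon. Going by the values given here, with only one earlier instance to draw on, this change is expected to give a 1.0-fold lower number from compound 3 to compound 4 (0.02 log units; within the scatter), because its earlier instance gave a 1.1-fold lower number from compound 1 to compound 2 (0.02 log units; within the scatter). The estimate for compound 4 is therefore 85000 nM, with an expected range from 45000 nM to 160000 nM.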

Compound 4, half-maximal effective concentration: 67000 nM
Compound 4: middle estimate off by 1.3-fold (0.10 log units), on the high side; the range from low to high includes it.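

In this assay, methyl in place of hydrogen on the oxygen gives a 1.3-fold lower number from compound 3 to compound 4 (0.12 log units; within the scatter), and the two cores agree on this change: the same change on two cores in this assay, a 1.1-fold lower number (0.02 log units; within the scatter) from compound 1 to compound 2 and a 1.3-fold lower number (0.12 log units; within the scatter) from compound 3 to compound 4, 1.3-fold (0.10 log units) apart, within the scatter of two such steps Across these two cores, then, hydroxy to methoxy leaves the number within the usual variation between repeated measurements, and the small step seen on the first core also holds on the second. This does not show that a sizeable effect carries from core to core, as neither step lies beyond the scatter, and two cores are too few to support a rule for the whole series.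

The compounds shown leave open whether a different group on that oxygen, such as ethyl or a longer chain, or an amine or a carboxylic acid in place of the hydroxy group, would move the number clearly. They also leave open what a group such as chlorine on the other aromatic ring would do.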